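The source may hold more compounds than are shown below. What is called first, only, known or untested is meant among the compounds shown, and "the series" means these compounds.

Working notes on the series in an assay on membranes from HEK293 cells for displacement of a labelled ligand from adenosine receptor A2b (Homo sapiens), read by scintillation counting, with a stated time of 30 min; on this read-out higher numbers stand for weaker inhibition and lower numbers for stronger inhibition. Compound 1 `CC1=C(C(=O)OCC(C)C)C(c2ccoc2)NC(=O)N1` gives 326 nM, the lowest of the three numbers recorded so far. Within the data shown here, compound 2 `CC1=C(C(=O)OCC(C)C)C(c2cccs2)NC(=O)N1` gives 2130 nM; the only single-point step measured is a 6.5-fold higher number from compound 1 to compound 2 (0.82 log units; beyond the scatter), which concerns thiophen-2-yl in place of furan-3-yl on a saturated ring carbon. Compound 3 `CC1=C(C(=O)C2CC2)C(c2ccco2)NC(=O)N1` gives 1060 nM; it differs from compound 1 in more than one place, so its value stands on its own. Compound 4 `CC1=C(C(=O)OCC2CC2)C(c2ccoc2)NC(=O)N1` differs from compound 1 as follows: cyclopropyl in place of isopropyl on a saturated chain carbon bound to an oxygen next to a carbonyl group. Among the measured compounds shown here, no measured step touches this position, so the change has no direct precedent; compound 4 is therefore expected to sit close to compound 1, with an expected step of a 1.1-fold higher number from compound 1 to compound 4 (0.03 log units; within the scatter), not beyond the scatter. The estimate for compound 4 is 350 nM, ranging from 150 nM to 800 nM.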

Compound 4, inhibition constant: 426 nM
Beside the measured number, compound 4's estimate is 1.2-fold (0.09 log units) below it, and the stated range covers the measured number.
By their numbers in this assay, from the lowest: compounds 1 and 4 (each within the scatter of the next); then compounds 3 and 2 (each within the scatter of the next).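

In this assay, among these compounds, a 1.3-fold higher number from compound 1 to compound 4 (0.12 log units; within the scatter) gives the first reading at this position, and cyclopropyl in place of isopropyl leaves the number within the scatter. With the same count of heavy atoms, the three-membered ring in cyclopropylmethyl and the open isobutyl chain therefore read alike here. Nothing available bears on the reason for this result. Open, going by these compounds, is how a longer chain or an amine in place of isobutoxy would read in this assay. Also open, on these data alone, is whether the same change would read alike with thiophen-2-yl in place of furan-3-yl.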